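Aryl exchange from compound 3 to compound 4

A few compounds are considered here, and "the series" means these few. Any claim that something is new, unique, unknown or untested is made for them only; others in the source may bear on it.

Measured in a functional assay on KBVIN cells (Homo sapiens) for antiproliferative activity, read by sulforhodamine B assay, with a stated time of 3 days; a higher number here means that more compound is needed for the effect, a lower number that less compound is needed:
- compound 1 `CCC1=C(O)c2c(oc(-c3ccccc3C)cc2=O)C(CC)(CC)C1=O`: 2.41 uM
- compound 2 `CCC1=C(O)c2c(oc(-c3ccccc3F)cc2=O)C(CC)(CC)C1=O`: 3.93 uM
- compound 3 `CCC1=C(O)c2c(oc(-c3ccc(OC)c(C)c3)cc2=O)C(CC)(CC)C1=O`: 0.1 uM

Compound 3 has the lowest number of the three, and its steps to both others lie beyond the scatter. Compound 4 `CCC1=C(O)c2c(oc(-c3cc(C)ccc3C)cc2=O)C(CC)(CC)C1=O` is not yet measured. Its difference from compound 3 is 2,5-dimethylphenyl in place of 4-methoxy-3-methylphenyl on an aromatic carbon: 2,5-dimethylphenyl enters in place of 4-methoxy-3-methylphenyl, on an aromatic carbon next to the ring oxygen.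

Two large measured steps exchange the group at this place: a 24-fold lower number from compound 1 to compound 3 (1.38 log units; beyond the scatter) and a 39-fold lower number from compound 2 to compound 3 (1.59 log units; beyond the scatter). By contrast, a 1.6-fold higher number from compound 1 to compound 2 (0.21 log units; within the scatter). Within the data shown here, the entering group contains the 2-methylphenyl of compound 1 plus one further methyl, whose contribution no measured compound isolates. Compound 1 is therefore taken as the closest guide, at 2.41 uM. A large step to a higher number in this assay is expected, though three compounds give thin support. The expected step is a 15-fold higher number from compound 3 to compound 4 (1.18 log units; beyond the scatter). For compound 4 the estimated value is 1.5 uM, with an expected range of 0.4 uM to 5 uM.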

Compound 4, concentration for half-maximal effect: 3.41 uM
Compound 4: middle estimate off by 2.3-fold (0.36 log units), on the low side; measured number inside the range.
By their numbers in this assay, from the lowest: compound 3; then compounds 1, 4 and 2 (each within the scatter of the next).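

Among these compounds, the further methyl that turns 2-methylphenyl into 2,5-dimethylphenyl, whose contribution no earlier compound isolated, stays within the scatter in this assay (a 1.4-fold higher number from compound 1 to compound 4 (0.15 log units; within the scatter)). The 2,5-dimethylphenyl group also lies within the scatter of 2-fluorophenyl (a 1.2-fold lower number from compound 2 to compound 4 (0.06 log units; within the scatter)), so compounds 1, 2 and 4 now form one level at this place. Compound 3 alone stands apart, and its exchange for 2,5-dimethylphenyl gives a step as large as the earlier ones (a 34-fold higher number from compound 3 to compound 4 (1.53 log units; beyond the scatter)), which makes 4-methoxy-3-methylphenyl the only group shown to set a different level.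

That exchange removes the methoxy and rearranges the methyl groups at once, so a plain 4-methoxyphenyl or 3-methylphenyl group would be needed to separate the two changes. Nothing at hand explains why the level differs at this place.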